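From a Fluorophenyl to a Dichlorophenyl Hydrazone

This account rests on a few compounds, and the source may have more. Where it says the series, first, only, none or still open, it means among the compounds named here.

Of the compounds shown here, three sharing one core have been measured in a functional assay on BGC-823 cells (Homo sapiens) for antiproliferative activity, read by MTT assay, tested at 5 uM; on this read-out lower numbers stand for a weaker effect and higher numbers for a stronger effect at the one concentration tested. Compound 1 `COc1ccc(/C=N/NC(=O)c2cc(OC)c(OC)c(OC)c2)c(OC)c1` gives 3.6%. Compound 2 `COc1cc(C(=O)N/N=C/c2cccc(C(F)(F)F)c2)cc(OC)c1OC` gives 33.8%. Compound 3 `COc1cc(C(=O)N/N=C/c2cccc(F)c2)cc(OC)c1OC` gives 44.8%, the highest of the three numbers; compound 2 stands nearest to it and compound 1 furthest, both beyond the scatter. Going by the values given here, the only step between two measured compounds that differ in one place is a number 11 percentage points higher from compound 2 to compound 3 (beyond the scatter), a modest gain.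

Compound 4 `COc1cc(C(=O)N/N=C/c2cc(Cl)cc(Cl)c2)cc(OC)c1OC` has not yet been measured. It differs from compound 3 in a single place: 3,5-dichlorophenyl in place of 3-fluorophenyl on a carbon with a double bond to nitrogen.

Among the compounds with values here, the step from compound 2 to compound 3 is the one measured change that bears on this position, and it shows that exchanging the group on this aromatic ring shifts the read-out by a modest amount. Within the data shown here, no measured compound carries chlorine on this ring or two substituents there, so the direction of the new step cannot be taken from the data. Compound 4 is therefore expected to land within a modest distance of compound 3, at an estimated 40%, with a range from 20% to 60%. The expected step is a number 4.8 percentage points lower from compound 3 to compound 4 (within the scatter).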

Compound 4, a percentage reported as inhibition, at one concentration (the size of the read-out at that concentration, not a potency): 9.2%
Beside the measured number, compound 4's estimate is 30.8 percentage points above it; the measured number lies below the stated range.
By their numbers in this assay, from the lowest: compounds 1 and 4 (each within the scatter of the next); then compound 2; then compound 3.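

The step of a number 35.6 percentage points lower from compound 3 to compound 4 (beyond the scatter) in this assay shows that this place can do far more than the modest a number 11 percentage points higher from compound 2 to compound 3 (beyond the scatter) suggested: exchanging the aromatic group on the carbon with a double bond to nitrogen can remove most of the read-out, leaving compound 4 at 9.2%. The shared core and the hydrazone link therefore do not secure activity at the one concentration tested, and a ring carrying a substituent is not enough either, as 3-fluorophenyl and 3,5-dichlorophenyl give very different numbers. No measurement available here accounts for the size of this step.

The step changes two things at once, the element on the ring and the number of substituents on it, so the compounds shown do not tell whether chlorine or the second substituent matters, and a 3-chlorophenyl group would separate the two. Also open is how a phenyl ring bearing an amine or a carboxylic acid would read at this place, and what potency any of these compounds has across a range of concentrations.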